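Two Triazole Pairs and the Loss of a Nitrile

The source may report more compounds than this note shows. Statements on the series, on what has been measured and on what is new or still open speak of the compounds shown alone.

Compound 1 `N#Cc1ccc(Cn2nccn2)cc1` and compound 2 `c1ccc(Cn2nccn2)cc1` form one measured pair. In an assay on isolated protein for inhibition of Aromatase (Homo sapiens), read by fluorescence and colorimetric assay, with a stated time of 30 min (on this read-out higher numbers stand for weaker inhibition and lower numbers for stronger inhibition), compound 1 gives 12200 nM, and compound 2 gives 16300 nM. The step between them is a 1.3-fold higher number from compound 1 to compound 2 (0.13 log units; within the scatter), and the change behind it is hydrogen in place of cyano on an aromatic carbon.

Compound 3 `N#Cc1ccc(Cn2cc(COc3ccccc3)nn2)cc1` carries a larger substituent on the triazole; in this assay compound 3 gives 6090 nM. The difference between the core of compound 3 and the core of compound 1 is not broken down here. Compound 4 `c1ccc(Cn2cc(COc3ccccc3)nn2)cc1` has not yet been measured. It differs from compound 3 by hydrogen in place of cyano on an aromatic carbon, the same kind of change as that from compound 1 to compound 2, though the surroundings differ: in the first pair the site is described as para to a group of 6 heavy atoms, in the second as para to a large group.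

Among the compounds with values here, since the only measured instance of this change, a 1.3-fold higher number from compound 1 to compound 2 (0.13 log units; within the scatter), stayed within the scatter, compound 4 is expected to land close to compound 3, with a step of about a 1.3-fold higher number from compound 3 to compound 4 (0.12 log units; within the scatter) in this assay. The estimate for compound 4 is therefore 8000 nM, expected to fall between 4000 nM and 16000 nM.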

Compound 4, half-maximal inhibitory concentration: 10600 nM
Compound 4: middle estimate off by 1.3-fold (0.12 log units), on the low side, within the range that was stated.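

In this assay, within the data shown here, putting hydrogen in place of cyano on the core of compound 3 gives a 1.7-fold higher number from compound 3 to compound 4 (0.24 log units; within the scatter), so the second pair, like the first, shows no step that stands clear of the usual variation between repeated measurements. Set beside each other, the two steps show that the change carries over from the core of compound 1 to the core of compound 3 without a detectable difference in its size: the same change on two cores in this assay, a 1.3-fold higher number (0.13 log units; within the scatter) from compound 1 to compound 2 and a 1.7-fold higher number (0.24 log units; within the scatter) from compound 3 to compound 4, 1.3-fold (0.11 log units) apart, within the scatter of two such steps. Among these compounds, this supports treating the change as transferable between these two cores on this read-out, but it rests on only two pairs, and it neither establishes that the nitrile contributes to inhibition nor shows that the change would read the same way on any other core.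

The compounds shown leave open how a different group on the same aromatic carbon, such as an amine, a carboxylic acid or a chlorine atom, would compare with cyano and hydrogen. They also leave open whether the agreement between the two pairs would hold if a longer chain or an amide stood on the triazole.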